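Working notes: 3-methoxyphenyl to 4-methoxyphenyl

The source may hold more compounds than are shown below. What is called first, only, known or untested is meant among the compounds shown, and "the series" means these compounds.

compound 1 `COc1ccccc1N1CCN(C(=O)/C=C/c2ccc(O)c(O)c2)CC1` gives 1.23 ug/mL
compound 2 `COc1cccc(N2CCN(C(=O)/C=C/c3ccc(O)c(O)c3)CC2)c1` gives 1.46 ug/mL

In a functional assay on B16-F10 cells (Mus musculus) for antiproliferative activity, read by MTT assay, with a stated time of 48 h (a higher number here means a weaker inhibitor, a lower number a stronger inhibitor), compound 2 gives 1.46 ug/mL and so stands level, within the scatter, with compound 1 at 1.23 ug/mL in the same read-out. Compound 3 `COc1ccc(N2CCN(C(=O)/C=C/c3ccc(O)c(O)c3)CC2)cc1` carries 4-methoxyphenyl in place of 3-methoxyphenyl on an amine nitrogen in a ring, with the same atoms joined differently. Within the data shown here, the one measured step that bears on this, also an exchange of one methoxyphenyl for another, is a 1.2-fold higher number from compound 1 to compound 2 (0.07 log units; within the scatter) and on that evidence no shift beyond the scatter is expected in this assay in either direction. Among the measured compounds shown here, this rests on a single step, and no measurement yet covers the 4-methoxyphenyl group. The expected step is a 1.0-fold lower number from compound 2 to compound 3 (0.02 log units; within the scatter) and it would leave the series flat so far. The estimate for compound 3 is 1.4 ug/mL as the expected value, with an expected range from 0.7 ug/mL to 2.8 ug/mL in this read-out.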

Compound 3, half-maximal inhibitory concentration: 1.21 ug/mL
Estimate against measurement, compound 3: 1.2-fold (0.06 log units) above; measured number inside the range.
By their numbers in this assay, from the lowest: compounds 3, 1 and 2 (each within the scatter of the next).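

Working from the three methoxyphenyl isomers, the change to 4-methoxyphenyl on an amine nitrogen in a ring gives, in this assay, a 1.2-fold lower number from compound 2 to compound 3 (0.08 log units; within the scatter) and a 1.0-fold lower number from compound 1 to compound 3 (0.01 log units; within the scatter) with both steps lying within the scatter. The earlier pair covered only the 2-methoxyphenyl and 3-methoxyphenyl groups, whereas the series now holds all three, and compound 1, compound 2 and compound 3 read level, so that in this read-out the place of the methoxy group on this phenyl ring does not separate the compounds. Nothing at hand bears on why these three compounds stand level.

As far as these compounds go, all three compounds carry a methoxy group on this phenyl ring, so the flat reading describes that one substituent only, and it remains open whether a chlorine, a nitro group, an amine or a longer alkoxy chain would read level across the same three places. Also open, from the compounds shown here alone, is how the number responds to a change elsewhere in the shared core, such as a carboxylic acid or a longer chain in place of the phenyl group on the ring nitrogen.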